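This account rests on a few compounds, and the source may have more. Where it says the series, first, only, none or still open, it means among the compounds named here.

Of the compounds shown here, three that share one core have been measured in a physicochemical assay for solubility; a higher number here means a more soluble compound, a lower number a less soluble compound. Compound 1 `O=C(c1ccccc1)N1CCC(NS(=O)(=O)c2cc(S(=O)(=O)c3ccccc3)ccc2C(F)(F)F)CC1` gives 12500 nM, compound 2 `CN(C)c1ccc(C(=O)N2CCC(NS(=O)(=O)c3cc(S(=O)(=O)c4ccccc4)ccc3C(F)(F)F)CC2)cc1` gives 50000 nM, and compound 3 `O=C(c1ccc(Cl)nc1)N1CCC(NS(=O)(=O)c2cc(S(=O)(=O)c3ccccc3)ccc2C(F)(F)F)CC1` gives 25000 nM. Compound 3 stands between the other two but cannot be separated from either, as a 2.0-fold higher number from compound 1 to compound 3 (0.30 log units; within the scatter) and a 2.0-fold lower number from compound 2 to compound 3 (0.30 log units; within the scatter) both lie within the scatter.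

Compound 4 `CN(C)c1ccc(C(=O)N2CCC(NS(=O)(=O)c3cc(S(=O)(=O)c4ccccc4)ccc3C(F)(F)F)CC2)cn1` takes dimethylamino in place of chloro on an aromatic carbon, next to the ring nitrogen and para to a large group: dimethylamino in place of chloro on an aromatic carbon. The closest measured precedent is a 4.0-fold higher number from compound 1 to compound 2 (0.60 log units; beyond the scatter), a modest step beyond the scatter in which dimethylamino replaced hydrogen rather than chloro. For the measured compounds named here, no measured step removes chloro from this position, so that precedent carries over only in part. A smaller rise in this assay is therefore expected, one that may not clear the scatter. The estimated step is a 1.8-fold higher number from compound 3 to compound 4 (0.26 log units; within the scatter). Compound 4 is expected to read about 45000 nM, within an estimated range of 20000 nM to 100000 nM.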

Compound 4, solubility: 12500 nM
The estimate for compound 4 lay 3.6-fold (0.56 log units) above the measured number, outside the stated range (below it).
By their numbers in this assay, from the lowest: compounds 1, 4, 3 and 2 (each within the scatter of the next, the first and the last beyond it).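

In this assay, dimethylamino in place of chloro on this aromatic carbon, next to the ring nitrogen, gives a 2.0-fold lower number from compound 3 to compound 4 (0.30 log units; within the scatter), so this change cannot be told apart from no change at all. The rise seen when dimethylamino entered on the phenyl ring of compound 2 does not carry over to the ring with one nitrogen: 6-(dimethylamino)pyridin-3-yl in place of 4-(dimethylamino)phenyl gives a 4.0-fold lower number from compound 2 to compound 4 (0.60 log units; beyond the scatter), and in place of phenyl it gives no change at the digits printed from compound 1 to compound 4 (within the scatter). No supporting evidence is available to explain why dimethylamino behaves differently on these two rings.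

From the compounds shown here alone, it remains open how a morpholine or a methoxy group would read on this same carbon. The compounds shown also leave open how a plain pyridin-3-yl, with only hydrogen there, would compare with compound 3 and compound 4.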